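The compounds below may be only part of what the source reports. "The series", "measured", "known", "first", "only" and "open" are said of these compounds alone.

In an assay on isolated protein for inhibition of serine/threonine-protein kinase TBK1 (Homo sapiens) (a lower number here means a stronger inhibitor, a higher number a weaker inhibitor), compound 1 `O=C(NCCCNc1nc(Nc2cccc(F)c2)ncc1Br)c1ccc(C(F)(F)F)cc1` gives 450 nM. Compound 2 `O=C(NCCCNc1nc(Nc2ccccc2F)ncc1C1CC1)c1cccs1`, which carries a different amide and a different substitution pattern on the shared core, gives 820 nM in this assay; the two numbers lie within the usual scatter of each other, so neither is set apart. Compound 3 `O=C(NCCCNc1nc(Nc2cccc(F)c2)ncc1Br)C1CCC1` differs from compound 1 by cyclobutyl in place of 4-(trifluoromethyl)phenyl on a carbonyl carbon. Among the measured compounds shown here, no measured pair shows this exchange. A modest loss, somewhat beyond the scatter, is expected from compound 1 to compound 3, a 2.2-fold higher number from compound 1 to compound 3 (0.35 log units; beyond the scatter). For compound 3 the estimate in this assay is 1000 nM, with a range from 300 nM to 3500 nM.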

Compound 3, half-maximal inhibitory concentration: 2 nM
Beside the measured number, compound 3's estimate is 500-fold (2.70 log units) above it; measured number outside the range, below it.
By their numbers in this assay, from the lowest: compound 3; then compounds 1 and 2 (each within the scatter of the next).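

Among the compounds shown here, at the carbonyl carbon of the amide, 4-(trifluoromethyl)phenyl is not required for inhibition in this assay: replacing it with cyclobutyl gives a 230-fold lower number from compound 1 to compound 3 (2.35 log units; beyond the scatter) and is the first single-place change to be read. The aromatic ring leaves, and the entering group has fewer heavy atoms, so this position tolerates a non-aromatic carbon ring and strongly influences the number. Nothing at hand accounts for the size of this step.

On these data alone, whether the gain is specific to cyclobutyl remains open, since neither cyclopentyl nor a straight butyl chain appears at this position. Also unresolved is whether an amine on that ring would be tolerated, or whether cyclobutyl has the same effect with cyclopropyl in place of bromine on the shared core.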